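Replacing the 4-(dimethylamino)phenyl group of compound 2

The compounds below may be only part of what the source reports. "The series", "measured", "known", "first", "only" and "open" are said of these compounds alone.

Compound 1 `CC1=CC[C@@H]([C@@](C)(O)CCCC(C)(C)NC(=S)N/N=C\c2ccc(O)cc2)CC1` gives 8870 nM in a functional assay on UACC-62 cells (Homo sapiens) for cytotoxicity, read by sulforhodamine B assay; on this read-out higher numbers stand for weaker inhibition of growth and lower numbers for stronger inhibition of growth
Compound 2 `CC1=CC[C@@H]([C@@](C)(O)CCCC(C)(C)NC(=S)N/N=C\c2ccc(N(C)C)cc2)CC1` gives > 100000 nM in this assay, a limit

Compound 2 stands only at a limit, > 100000 nM, and not at a number. Compound 3 `CC1=CC[C@@H]([C@@](C)(O)CCCC(C)(C)NC(=S)N/N=C\c2cccc([N+](=O)[O-])c2)CC1` differs from it as follows: 3-nitrophenyl in place of 4-(dimethylamino)phenyl on a carbon with a double bond to nitrogen. Going by the values given here, one measured step bears on this change, the large at least 11-fold higher number from compound 1 to compound 2 (1.05 log units; beyond the scatter), where dimethylamino took the place of hydroxy on an aromatic carbon. As dimethylamino leaves again in compound 3, a large step to a lower number in this assay is expected, though not all the way to compound 1 at 8870 nM. The expected step is an at least 5.0-fold lower number from compound 2 to compound 3 (0.69 log units; beyond the scatter). For compound 3 the estimate is 20000 nM, with an expected range from 5000 nM to 80000 nM.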

Compound 3, concentration for 50% growth inhibition: 7840 nM
The estimate for compound 3 lay 2.6-fold (0.41 log units) above the measured number; low and high end bracket the measured number.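

In this assay, the step is an at least 12-fold lower number from compound 2 to compound 3 (1.10 log units; beyond the scatter), so at this place a 4-hydroxyphenyl group is not required to regain growth inhibition. With 3-nitrophenyl in place of 4-hydroxyphenyl there is a 1.1-fold lower number from compound 1 to compound 3 (0.05 log units; within the scatter), which shows two quite different aromatic groups giving matching values, with compound 2 alone going against them. Compound 2 is a limit, not a number: the limit of > 100000 nM in this assay, at which 1 of the 3 values shown sits.

Going by these compounds, what a plain phenyl, an amine or a carboxylic acid would do on this ring stays open. So does whether any group here can take the values clearly lower than those of compound 1 and compound 3.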